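The source may report more compounds than this note shows. Statements on the series, on what has been measured and on what is new or still open speak of the compounds shown alone.

Compound 1 `CN1C(=O)N(C)C2C1NC(=S)N2/N=C/C=C/c1ccccc1` was tested in a functional assay on A549 cells (Homo sapiens) for inhibition, read by MTT assay, with a stated time of 72 h; a lower number here means a stronger inhibitor, a higher number a weaker inhibitor. In this assay compound 1 gives 45700 nM. Compound 2 `COc1ccc(/C=C/C=N/N2C(=S)NC3C2N(C)C(=O)N3C)cc1` differs from it by one change, (methoxy in place of hydrogen on an aromatic carbon). In this assay compound 2 gives > 100000 nM, which is a limit of the assay and not a number. That change made an at least 2.1-fold higher number from compound 1 to compound 2 (0.34 log units; beyond the scatter).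

Compound 3 `CCN1C(=O)N(c2ccccc2)C2NC(=S)N(/N=C/C=C/c3ccccc3)C21` is built on a different core, and the difference between the two cores is not broken down here. In this assay compound 3 gives > 100000 nM, again a limit of the assay. Compound 4 `CCN1C(=O)N(c2ccccc2)C2NC(=S)N(/N=C/C=C/c3ccccc3OC)C21` is not yet measured; it differs from compound 3 by methoxy in place of hydrogen on an aromatic carbon. For the measured compounds named here, this is the same kind of change as the one from compound 1 to compound 2, but the place differs: there the methoxy sits para to a large group, here ortho to a large group.

The step from compound 3 to compound 4 in this assay is estimated as a step that the limit leaves unreadable from compound 3 to compound 4, expected to hold the weak inhibition because the limit of > 100000 nM in this assay, at which 2 of the 3 values shown sit, and the earlier step added methoxy and lost rather than gained strength. Compound 4 is therefore expected at about 150000 nM, with a range of 50000 nM to 500000 nM, most likely reported only as a limit.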

Compound 4, half-maximal inhibitory concentration: > 100000 nM
Compound 4 was reported as a limit (the forecaster's own chance of this, stated with the estimate: 80%); the middle value does not contradict the limit.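

The step from compound 3 to compound 4 cannot be read, because both results are limits of the assay and not numbers: the limit of > 100000 nM in this assay, at which 3 of the 4 values shown sit.

The compounds shown leave open whether methoxy in place of hydrogen on an aromatic carbon changes inhibition on the core of compound 3, and what true values lie behind these limits.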